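A few compounds are considered here, and "the series" means these few. Any claim that something is new, unique, unknown or untested is made for them only; others in the source may bear on it.

Going by the values given here, in a functional assay on KBVIN cells (Homo sapiens) for cytotoxicity, read by MTT assay, with a stated time of 72 h (a lower number here means that less compound is needed, a higher number that more compound is needed for the effect), compound 2 (`COc1ccc(Nc2cc(/C=C/c3ccccc3)oc(=O)c2)cc1`) gives 0.1 uM, the lowest of the three numbers measured so far. Compound 4 (`COc1ccc(Nc2cc(C3CCCC3)oc(=O)c2)cc1`) has cyclopentyl in place of 2-phenylethenyl on an aromatic carbon, next to the ring oxygen: cyclopentyl in place of 2-phenylethenyl on an aromatic carbon. Among the compounds with values here, the only measured step, a 12-fold lower number from compound 1 to compound 2 (1.09 log units; beyond the scatter), is large and beyond the scatter, but it concerns the group on the nitrogen, so it gives no direct size for a change at this carbon. Within the data shown here, no measured compound carries cyclopentyl, and the values offer only indirect guidance. Among the measured compounds shown here, compound 3 (`O=c1cc(NC2CCCCC2)cc(-c2ccccc2)o1`), the only measured compound without 2-phenylethenyl, gives 9.15 uM, a higher number than compound 1 (`O=c1cc(NC2CCCCC2)cc(/C=C/c2ccccc2)o1`), which gives 1.24 uM. Losing 2-phenylethenyl is therefore expected to raise the number in this assay, and the expected change is a 15-fold higher number from compound 2 to compound 4 (1.18 log units; beyond the scatter), a large step beyond the scatter. For compound 4 the estimated value is 1.5 uM, with an expected range from 0.3 uM to 10 uM.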

Compound 4, concentration for half-maximal effect: 4.98 uM
The estimate for compound 4 lay 3.3-fold (0.52 log units) below the measured number; measured number inside the range.
By their numbers in this assay, from the lowest: compound 2; then compound 1; then compounds 4 and 3 (each within the scatter of the next).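

Replacing 2-phenylethenyl with cyclopentyl on this carbon gives the first direct size for a change here: a 50-fold higher number from compound 2 to compound 4 (1.70 log units; beyond the scatter) in this assay. Compound 2 therefore does not keep its low number through the 4-methoxyphenyl on the nitrogen alone, since compound 4 carries that same group and still moves far up the scale, even though neither group exchanged has a hydrogen-bond donor or acceptor. No measurement at hand explains the size of this step.

The single change removes an aromatic ring and a double bond and also shortens the group, so the compounds shown do not separate these features. From the compounds shown here alone, whether 2-phenylethyl, with its ring but no double bond, would stay close to compound 2, or whether an amine on the ring of 2-phenylethenyl would be tolerated, remains open.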